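A few compounds are considered here, and "the series" means these few. Any claim that something is new, unique, unknown or untested is made for them only; others in the source may bear on it.

In a functional assay on L6 cells (Rattus norvegicus) for inhibition, read by scintillation counting, with a stated time of 3 h (a lower number here means a stronger inhibitor, a higher number a weaker inhibitor), compound 1 `COc1ccccc1CNC(=O)c1nc(-c2ccc(F)cc2)n(CC[C@@H](O)C[C@@H](O)CC(=O)O)c1C1CC1` gives 10700 nM and compound 2 `CC(C)c1c(C(=O)NCc2ccccc2)nc(-c2ccc(F)cc2)n1CC[C@@H](O)C[C@@H](O)CC(=O)O` gives 3030 nM. Compound 2 holds the lower of the two numbers, and the gap to compound 1 lies beyond the scatter, so compound 2 is the stronger inhibitor of this pair. Compound 3 `O=C(O)C[C@H](O)C[C@H](O)CCn1c(-c2ccc(F)cc2)nc(C(=O)NCc2ccccc2)c1C1CC1` changes one place on compound 2: cyclopropyl in place of isopropyl on an aromatic carbon. For the measured compounds named here, no measured step isolates this swap. Going by the values given here, the only measured compound with cyclopropyl, compound 1 at 10700 nM, tilts the expectation toward a higher number, though it is not a clean comparison. The expected change is small, toward weaker inhibition and close to the scatter: a 1.8-fold higher number from compound 2 to compound 3 (0.26 log units; within the scatter). The value expected for compound 3 is 5500 nM, with an estimated range of 1800 nM to 15000 nM.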

Compound 3, half-maximal inhibitory concentration in the L6 assay: 632 nM
Estimate against measurement, compound 3: 8.7-fold (0.94 log units) above; measured number below the stated range.
By their numbers in the L6 assay, from the lowest: compound 3; then compound 2; then compound 1.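

In the L6 assay, cyclopropyl in place of isopropyl on this aromatic carbon, next to the ring nitrogen, gives a 4.8-fold lower number from compound 2 to compound 3 (0.68 log units; beyond the scatter), so at this position in the benzylcarbamoyl series the swap favours inhibition. In the L6 assay, hydrogen in place of methoxy gives a 17-fold lower number from compound 1 to compound 3 (1.23 log units; beyond the scatter), so the weak number of compound 1 cannot be read as a cost of cyclopropyl, since compound 3 carries the same group without the methoxy. In a physicochemical assay for lipophilicity, using the shake flask method, at pH 7.4 (on this read-out lower numbers stand for lower lipophilicity and higher numbers for higher lipophilicity), compound 2 gives 0.64 and compound 3 gives 0.03. The gain in inhibition also comes with lower lipophilicity: the measured distribution coefficient of compound 2, 0.64, and of compound 3, 0.03, a number 0.61 log units lower (beyond the scatter)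

A methyl or a cyclobutyl on the same carbon would test whether the gain is specific to the three-membered ring. Going by these compounds, whether the methoxy step carries over to the isopropyl compounds stays open.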